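The source may report more compounds than this note shows. Statements on the series, on what has been measured and on what is new or still open speak of the compounds shown alone.

Working notes on the series. In a functional assay on DU-145 cells (Homo sapiens) for cytotoxicity, read by sulforhodamine B assay, with a stated time of 48 h (on this read-out lower numbers stand for stronger inhibition of growth and higher numbers for weaker inhibition of growth), compound 1 (`CC(=O)N1CCN(c2nc(Nc3ccc(C#N)c(C(F)(F)F)c3)nc(Oc3ccnc4ccccc34)n2)CC1`) reads > 100000 nM as a limit of the assay and not a number (the limit of > 100000 nM in this assay, at which 1 of the 2 values shown sits). Compound 2 (`CC1CC(C)CN(c2nc(Nc3ccc(C#N)c(C(F)(F)F)c3)nc(Oc3ccnc4ccccc34)n2)C1`) gives 68000 nM in this assay with 3,5-dimethylpiperidin-1-yl in place of 4-acetylpiperazin-1-yl. This only measured step (an at least 1.4-fold lower number from compound 1 to compound 2 (0.16 log units; that floor lies within the scatter)) has a floor within the scatter. Compound 3 (`N#Cc1ccc(Nc2nc(Oc3ccnc4ccccc34)nc(N3CCN(c4cccc(C(F)(F)F)c4)CC3)n2)cc1C(F)(F)F`) carries 3-(trifluoromethyl)phenyl in place of acetyl on an amine nitrogen in a ring. Going by the values given here, the only guide is compound 2 at 68000 nM in this assay, and it concerns a different replacement, so the guidance is weak. A small move to a lower number is expected in this assay, estimated as (an at least 2.0-fold lower number from compound 1 to compound 3 (0.30 log units; that floor lies within the scatter)). A reading at the limit also remains possible. For compound 3 the estimated value is 50000 nM (expected range 15000 nM to 100000 nM).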

Compound 3, concentration for total growth inhibition: 74100 nM
For compound 3 the middle estimate is 1.5-fold (0.17 log units) below the measured one; the range from low to high includes it.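

On the amine nitrogen of the six-membered non-aromatic ring with 2 nitrogen, 3-(trifluoromethyl)phenyl in place of acetyl gives an at least 1.3-fold lower number from compound 1 to compound 3 (0.13 log units; that floor lies within the scatter) in this assay. Compound 1 stands at a limit of the assay and not at a number: the limit of > 100000 nM in this assay, at which 1 of the 3 values shown sits. As far as these compounds go, the true size of this step therefore stays unknown, but compound 3 shows that this ring, kept intact and carrying an aromatic ring on that nitrogen, can give a numerical reading, which compound 2 could not show with its 3,5-dimethylpiperidin-1-yl group.

The compounds shown leave open whether the trifluoromethyl group or the phenyl ring itself goes with this reading. A plain phenyl, a benzyl group or a short chain ending in an amine on the same nitrogen would separate these possibilities.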